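Cyano for isopropoxy in a level series

This account rests on a few compounds, and the source may have more. Where it says the series, first, only, none or still open, it means among the compounds named here.

In an ADME assay on L6 cells (Rattus norvegicus) for cytotoxicity, read by resazurin assay, with a stated time of 72 h (a higher number here means a weaker inhibitor, a lower number a stronger inhibitor), three compounds have been measured:
compound 1 `Cc1ccc(C(O)(c2ccc(Cl)cc2)c2cccnc2)cc1`: 61000 nM
compound 2 `OC(c1ccc(Cl)cc1)(c1ccc(Br)cc1)c1cccnc1`: 57000 nM
compound 3 `CC(C)Oc1ccc(C(O)(c2ccc(Cl)cc2)c2cccnc2)cc1`: 56600 nM

Compound 3 lies within the scatter of both others, so it holds no distinct place among them. Compound 4 `N#Cc1ccc(C(O)(c2ccc(Cl)cc2)c2cccnc2)cc1` differs from it by cyano in place of isopropoxy on an aromatic carbon, para to a large group: cyano in place of isopropoxy on an aromatic carbon. Three measured steps at this same place bear on the change: a 1.1-fold lower number from compound 1 to compound 2 (0.03 log units; within the scatter), a 1.1-fold lower number from compound 1 to compound 3 (0.03 log units; within the scatter) and a 1.0-fold lower number from compound 2 to compound 3 (0.00 log units; within the scatter). All stay within the scatter, though none involves cyano. No step beyond the scatter is therefore expected in this assay. The estimated step is a 1.0-fold higher number from compound 3 to compound 4 (0.01 log units; within the scatter). For compound 4 the estimate is 58000 nM, with an expected range of 32000 nM to 95000 nM.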

Compound 4, half-maximal inhibitory concentration: > 100000 nM
Compound 4 gave a limit, no number; the forecaster's own chance of this, stated with the estimate: 15%; at least 1.7-fold (0.23 log units) between middle value and limit.
By their numbers in this assay, from the lowest: compounds 3, 2 and 1 (each within the scatter of the next). At a limit, above all of these: compound 4.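

In this assay, compound 4 gave a limit of the assay and no number: the limit of > 100000 nM in this assay, at which 1 of the 4 values shown sits. Cyano is the first group at this position, on an aromatic carbon para to a large group, to yield no number, and the change reads as an at least 1.7-fold higher number from compound 3 to compound 4 (0.24 log units; that floor lies within the scatter), as an at least 1.7-fold higher number from compound 2 to compound 4 (0.24 log units; that floor lies within the scatter) and as an at least 1.6-fold higher number from compound 1 to compound 4 (0.21 log units; that floor lies within the scatter). These are floors only, so the series may have stayed level or may have shifted well beyond the scatter. The compounds shown leave open how far compound 4 truly lies from the others, and whether an amine or a carboxylic acid at this place would also give a limit.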